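A few compounds are considered here, and "the series" means these few. Any claim that something is new, unique, unknown or untested is made for them only; others in the source may bear on it.

Of the compounds shown here, three that share one core have been tested in an ADME assay on the whole organism (Mus musculus, strain C57BL/6J) for pharmacokinetics, with a stated time of 24 h, at a dose of 2 mg/kg by the intravenous route; on this read-out higher numbers stand for fast clearance and lower numbers for slow clearance. Compound 1 `CCCCOc1nc(OCC(C)(C)O)c(-c2ccc(S(C)(=O)=O)cc2)cc1CO`, which carries a 2-hydroxy-2-methylpropoxy group, gives 101 mL/min/kg. Compound 2 `CCCCOc1nc(-c2ccc(F)cc2)c(-c2ccc(S(C)(=O)=O)cc2)cc1CO`, with 4-fluorophenyl in that place, gives 32.2 mL/min/kg. Compound 3 `CCCCOc1nc(OCC2COC2)c(-c2ccc(S(C)(=O)=O)cc2)cc1CO`, with (oxetan-3-yl)methoxy there, gives 102 mL/min/kg, so it sits level with compound 1 at the fast-clearance end, while compound 2 lies clearly lower.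

Compound 4 `CCCCOc1nc(OCC2(O)COC2)c(-c2ccc(S(C)(=O)=O)cc2)cc1CO` keeps everything in compound 3 except for one change: hydroxy in place of hydrogen on a saturated ring carbon. In words, hydroxy stands in place of hydrogen on a saturated ring carbon, giving (3-hydroxyoxetan-3-yl)methoxy. Among the compounds with values here, no measured pair makes this exact change. The closest evidence is the exchange of 1-hydroxy-1-methylethyl for oxetan-3-yl, which gave a 1.0-fold higher number from compound 1 to compound 3 (0.00 log units; within the scatter). Here, a chain end with a hydroxy and a chain end with the oxetane ring gave the same result, and compound 4 carries both features. Within the data shown here, the only sizeable steps, a 3.1-fold lower number from compound 1 to compound 2 (0.50 log units; beyond the scatter) and a 3.2-fold higher number from compound 2 to compound 3 (0.50 log units; beyond the scatter), both involve the 4-fluorophenyl group, a far larger replacement, so they say little here.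

In this assay, no step beyond the scatter is therefore expected, perhaps a slight drop. The expected step is a 1.1-fold lower number from compound 3 to compound 4 (0.05 log units; within the scatter). The estimate for compound 4 is 90 mL/min/kg, with an expected range from 48 mL/min/kg to 150 mL/min/kg.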

Compound 4, clearance: 68.6 mL/min/kg
The estimate for compound 4 lay 1.3-fold (0.12 log units) above the measured number; the measured number falls inside the stated range.
By their numbers in this assay, from the lowest: compound 2; then compounds 4, 1 and 3 (each within the scatter of the next).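

Placing hydroxy on the saturated ring carbon, which turns oxetan-3-yl into 3-hydroxyoxetan-3-yl, gives in this assay (a 1.5-fold lower number from compound 3 to compound 4 (0.17 log units; within the scatter)), so this first direct test of the change shows no step that can be told apart from the scatter. Exchanging the open-chain 1-hydroxy-1-methylethyl end for 3-hydroxyoxetan-3-yl also stays within the scatter (a 1.5-fold lower number from compound 1 to compound 4 (0.17 log units; within the scatter)), which leaves compounds 1, 3 and 4 level with one another, while the exchange of 4-fluorophenyl for the (3-hydroxyoxetan-3-yl)methoxy group still makes a modest step beyond the scatter (a 2.1-fold higher number from compound 2 to compound 4 (0.33 log units; beyond the scatter)). Nothing shown here gives a measured reason for any of these numbers.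

On these data alone, it remains open whether an amine or a carboxylic acid on the same ring carbon, in place of the hydroxy, would give a step beyond the scatter. As far as these compounds go, it also remains open whether a longer chain between the ring and the ether oxygen would stay level with compounds 1, 3 and 4, or whether it would come closer to compound 2.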